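This account rests on a few compounds, and the source may have more. Where it says the series, first, only, none or still open, it means among the compounds named here.

- Compound 1 `COc1cccc(-c2oc3ccc(NC(C)=O)cc3c(=O)c2O)c1`: 33300 nM
- Compound 2 `CC(=O)Nc1ccc2oc(-c3ccc(F)cc3)c(O)c(=O)c2c1`: 34100 nM
- Compound 3 `COc1cccc(-c2oc3ccc(N)cc3c(=O)c2O)c1`: 40800 nM

These numbers come from an ADME assay on MT4 cells (Homo sapiens) for cytotoxicity, read by MTT assay, with a stated time of 4 days; a higher number here means that more compound is tolerated, a lower number that less compound is tolerated. On them, compound 1 stands level with the other two. Putting 4-fluorophenyl in place of 3-methoxyphenyl gives a 1.0-fold higher number from compound 1 to compound 2 (0.01 log units; within the scatter), and putting hydrogen in place of acetyl on the nitrogen gives a 1.2-fold higher number from compound 1 to compound 3 (0.09 log units; within the scatter).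

The next compound is compound 4 `COc1cccc(-c2oc3ccc(NC(C)=O)cc3c(=O)c2OC)c1`, and its change from compound 1 is methyl in place of hydrogen on an oxygen on an aromatic ring, or hydroxy to methoxy. Neither measured step touches this hydroxy, so no direct evidence for this change exists. The two steps bear on it only indirectly, showing that changes elsewhere on the shared core left this assay within the scatter. No step beyond the scatter is therefore expected, though with real uncertainty. The expected step is a 1.1-fold higher number from compound 1 to compound 4 (0.06 log units; within the scatter). Compound 4 is estimated at 38000 nM, with an expected range of 17000 nM to 85000 nM.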

Compound 4, half-maximal cytotoxic concentration: 369000 nM
For compound 4 the middle estimate is 9.7-fold (0.99 log units) below the measured one, and the stated range ends below it.
By their numbers in this assay, from the lowest: compounds 1, 2 and 3 (each within the scatter of the next); then compound 4.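

In this assay, the hydroxy on the shared core is the one place among those shown where a small change moves the number well beyond the scatter: hydroxy to methoxy gives an 11-fold higher number from compound 1 to compound 4 (1.04 log units; beyond the scatter). The earlier changes, at the other two places, stayed within the scatter, so this core is not insensitive to every edit, and a single added methyl on this oxygen counts for more here than replacing 3-methoxyphenyl with 4-fluorophenyl. Nothing available explains why this step is so large.

Still open, as far as these compounds go, is whether losing the hydrogen on this oxygen is what matters, or whether a longer chain such as ethyl, or an amine in place of the hydroxy, would read the same. From the compounds shown here alone, whether the step holds on the cores of compound 2 and compound 3 also stays open.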